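A few compounds are considered here, and "the series" means these few. Any claim that something is new, unique, unknown or untested is made for them only; others in the source may bear on it.

Measured compounds:
compound 1 `COc1cc2c(Oc3ccc(NC(=O)c4nn(-c5ccccc5F)c(=O)c5ccccc45)cc3F)ccnc2cc1OCCCN1CCCC1` gives 230 nM in a functional assay on NCI-H460 cells (Homo sapiens) for cytotoxicity, read by MTT assay, with a stated time of 72 h; on this read-out higher numbers stand for weaker inhibition and lower numbers for stronger inhibition;
compound 2 `COc1cc2c(Oc3ccc(NC(=O)c4nn(-c5ccc(Br)cc5)c(=O)c5ccccc45)cc3F)ccnc2cc1OCCCN1CCCC1` gives 180 nM in this assay;
compound 3 `COc1ccc(-n2nc(C(=O)Nc3ccc(Oc4ccnc5cc(OCCCN6CCCC6)c(OC)cc45)c(F)c3)c3ccccc3c2=O)cc1` gives 1650 nM in this assay.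

Compound 2 gives the lowest number of the three, though compound 1 sits within the scatter of it, as a 1.3-fold lower number from compound 1 to compound 2 (0.11 log units; within the scatter) shows; compound 3 lies further off, with a 9.2-fold higher number from compound 2 to compound 3 (0.96 log units; beyond the scatter).

Compound 4 `COc1cc2c(Oc3ccc(NC(=O)c4nn(-c5ccc(Br)cc5)c(=O)c5ccccc45)cc3F)ccnc2cc1OCCCN1CCN(C)CC1` differs from compound 2 in the tail: 4-methylpiperazin-1-yl in place of pyrrolidin-1-yl on a saturated chain carbon, three bonds along the chain from an oxygen on an aromatic ring. Going by the values given here, none of the measured steps touches this chain end; each of them, a 1.3-fold lower number from compound 1 to compound 2 (0.11 log units; within the scatter), a 7.2-fold higher number from compound 1 to compound 3 (0.86 log units; beyond the scatter) and a 9.2-fold higher number from compound 2 to compound 3 (0.96 log units; beyond the scatter), changes only the aryl group on the aromatic nitrogen. Among the compounds with values here, no measured step therefore bears on this change, and no step beyond the scatter is expected in this assay.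

Compound 4 is accordingly estimated at 200 nM, between 80 nM and 500 nM, an expected step of a 1.1-fold higher number from compound 2 to compound 4 (0.05 log units; within the scatter).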

Compound 4, half-maximal inhibitory concentration: 250 nM
The estimate for compound 4 lay 1.3-fold (0.10 log units) below the measured number, within the range that was stated.
By their numbers in this assay, from the lowest: compounds 2, 1 and 4 (each within the scatter of the next); then compound 3.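

In this assay, going by these compounds alone, the change of tail gives a 1.4-fold higher number from compound 2 to compound 4 (0.14 log units; within the scatter) and is the first measured step at this chain end, since the earlier steps changed only the aryl group on the aromatic nitrogen. In this one pair, with 4-bromophenyl on that nitrogen, 4-methylpiperazin-1-yl takes the place of pyrrolidin-1-yl without a step beyond the scatter. No evidence is available to explain this result. Going by these compounds, whether the same holds with 2-fluorophenyl or 4-methoxyphenyl on that nitrogen remains open. So does the outcome with a morpholine ring, an open-chain dimethylamino group or a longer chain.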